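Amide-side azole replacement on the shared core

This account rests on a few compounds, and the source may have more. Where it says the series, first, only, none or still open, it means among the compounds named here.

Measured so far:
compound 1 `COC1CCN(CC(=O)N2CCN(c3sc(C(F)(F)F)nc3-c3nc4ccccc4[nH]3)C[C@H]2C)C1`: 3380 nM
compound 2 `Cc1nc(C)n(CC(=O)N2CCN(c3sc(C(F)(F)F)nc3-c3nc4ccc(C5CCN(C)CC5)cc4[nH]3)C[C@H]2C)n1`: 84.7 nM
compound 3 `Cc1nc(C)n(CC(=O)N2CCN(c3sc(C(F)(F)F)nc3-c3nc4cccc(C)c4[nH]3)C[C@H]2C)n1`: 376 nM

In a functional assay on Venous blood for antagonist activity at C-X-C chemokine receptor type 3 (Homo sapiens), read by flow cytometry, with a stated time of 30 min, in the presence of a further agent that is not named here (a higher number here means a weaker inhibitor, a lower number a stronger inhibitor), compound 1 gives 3380 nM, the highest of the three numbers; compound 3 sits nearer to it and compound 2 furthest away, both gaps beyond the scatter. Among the measured compounds shown here, compounds 2 and 3 carry an aromatic azole on the carbon bound to the carbonyl, where compound 1 has a saturated ring, though they also differ from compound 1 elsewhere, so no single step is isolated.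

Compound 4 `C[C@@H]1CN(c2sc(C(F)(F)F)nc2-c2nc3ccccc3[nH]2)CCN1C(=O)Cn1cc(C2CCN(C)CC2)cn1` is not yet measured. It differs from compound 1 by 4-(1-methylpiperidin-4-yl)-1H-pyrazol-1-yl in place of 3-methoxypyrrolidin-1-yl on a saturated chain carbon bound to a carbonyl carbon. On the numbers for compounds 2 and 3, a move toward lower values is expected, of moderate size. The step of an 11-fold lower number from compound 1 to compound 4 (1.02 log units; beyond the scatter) is an estimate. Compound 4 is expected to give about 320 nM, within 80 nM to 1300 nM.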

Compound 4, half-maximal inhibitory concentration: 1690 nM
Compound 4: the middle estimate sits 5.3-fold (0.72 log units) below what was measured; the whole stated range lies below it.
By their numbers in this assay, from the lowest: compound 2; then compound 3; then compounds 4 and 1 (each within the scatter of the next).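

In this assay, among the compounds shown here, 4-(1-methylpiperidin-4-yl)-1H-pyrazol-1-yl in place of 3-methoxypyrrolidin-1-yl gives a 2.0-fold lower number from compound 1 to compound 4 (0.30 log units; within the scatter) on the shared core, the only single-place reading at this position. This aromatic azole on a saturated chain carbon bound to a carbonyl carbon therefore leaves the two numbers indistinguishable. Nothing available explains this result.

Open, from the compounds shown here alone, is how the azole of compounds 2 and 3 would read on the core of compound 1. Also open, going by these compounds, is whether a carboxylic acid or primary amine in place of the 1-methylpiperidin-4-yl part would separate from compound 1.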